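This account rests on a few compounds, and the source may have more. Where it says the series, first, only, none or still open, it means among the compounds named here.

In a functional assay on PC-3 cells (Homo sapiens) for antiproliferative activity, read by MTT assay, with a stated time of 48 h (a higher number here means a weaker inhibitor, a lower number a stronger inhibitor), compound 1 (`C#CC(C)OC(=O)c1ccc(C(CC)(CC)c2ccc(OCCC(O)(CC)CC)c(C)c2)n1CC`) gives 14800 nM and compound 2 (`CCn1c(C(=O)N(C)CCO)ccc1C(CC)(CC)c1ccc(OCCC(O)(CC)CC)c(C)c1`) gives 3090 nM, the lower of the two numbers and so the stronger inhibitor of this pair. Compound 3 (`CCn1c(C(=O)NC(CO)CCO)ccc1C(CC)(CC)c1ccc(OCCC(O)(CC)CC)c(C)c1`) is still unmeasured. The change from compound 2 is a group of 7 heavy atoms (4 carbon, 1 nitrogen, 2 oxygen; no ring) in place of a group of 5 heavy atoms (3 carbon, 1 nitrogen, 1 oxygen; no ring), on a carbonyl carbon, made on a carbonyl carbon whose other neighbour is an aromatic carbon, with the rest of the structure unchanged.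

For the measured compounds named here, only one measured step bears on this: a 4.8-fold lower number from compound 1 to compound 2 (0.68 log units; beyond the scatter), with (2-hydroxyethyl)(methyl)amino in place of (1-methylprop-2-yn-1-yl)oxy on a carbonyl carbon. It was a modest step at the same place, so changes here can move the number in this assay. However, it is a single step, and no measured compound carries the entering group, so it sets no trend. No step beyond the scatter is therefore expected, with only a slight lean towards a lower number. The expected change is a 1.2-fold lower number from compound 2 to compound 3 (0.09 log units; within the scatter), and the wide range reflects how little the data constrain it. Compound 3 is estimated at 2500 nM, with an expected range of 800 nM to 8000 nM.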

Compound 3, half-maximal inhibitory concentration: 8760 nM
Compound 3: the middle estimate sits 3.5-fold (0.54 log units) below what was measured; measured number above the stated range.
By their numbers in this assay, from the lowest: compound 2; then compounds 3 and 1 (each within the scatter of the next).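

At this carbonyl carbon, this assay now shows that the response does not simply follow from replacing the (1-methylprop-2-yn-1-yl)oxy group with a hydroxylated amide: the larger group with 3 hydrogen-bond donors goes with a 2.8-fold higher number from compound 2 to compound 3 (0.45 log units; beyond the scatter). Set against the ester of the shared core, the same group gives a 1.7-fold lower number from compound 1 to compound 3 (0.23 log units; within the scatter), so the gain seen with (2-hydroxyethyl)(methyl)amino is not carried over to this second amide, and compound 2 remains the strongest inhibitor of the three. The results on hand give no measured basis for explaining this difference.

Compound 3 differs from compound 2 at once in the amide hydrogen, the branched chain and the added hydroxyl, so these three compounds do not separate the contribution of each feature. Also open, going by these compounds, is how a simple primary amide, a carboxylic acid or a longer hydroxyalkyl chain on the same carbonyl carbon would read in this assay, and whether any of them would fall below the level of compound 2.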